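A few compounds are considered here, and "the series" means these few. Any claim that something is new, unique, unknown or untested is made for them only; others in the source may bear on it.

Measured so far in a functional assay on MV4-11 cells (Homo sapiens) for inhibition, read by luminescence and CellTiter-Glo, with a stated time of 72 h; a higher number here means a weaker inhibitor, a lower number a stronger inhibitor:

compound 1 `CCN1CCN(c2c(C(C)=O)c(=O)oc3cc(Nc4ncc(F)c(-c5ccc(F)cc5OC)n4)ccc23)CC1` — 550 nM
compound 2 `CCN1CCN(c2c(C(C)=O)c(=O)oc3cc(Nc4nccc(-c5ccc(F)cc5OC)n4)ccc23)CC1` — 740 nM
compound 3 `COc1ccccc1-c1ccnc(Nc2ccc3c(N4CCNCC4)cc(=O)oc3c2)n1` — 1340 nM

Compound 1 holds the lowest of the three numbers. Going by the values given here, its nearest neighbour is compound 2, and the only single-point step in the set, a 1.3-fold higher number from compound 1 to compound 2 (0.13 log units; within the scatter), is within the scatter, so compounds 1 and 2 cannot be told apart. Among the compounds with values here, compound 3 stands furthest from compound 1; it differs in several places at once, so no single step is computed for that pair, and the two values show only that compound 3 gives the higher number, beyond the scatter.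

Compound 4 `COc1cc(F)ccc1-c1nc(Nc2ccc3c(N4CCCNCC4)c(C(C)=O)c(=O)oc3c2)ncc1F` is not yet measured. Relative to compound 1 the change is 1,4-diazepan-1-yl in place of 4-ethylpiperazin-1-yl on an aromatic carbon; the acetyl group and the fluoro on the pyrimidine are kept. Within the data shown here, no measured step touches this amine ring, and the step from compound 1 to compound 2 concerns a different position and does not bear on it. The higher number of compound 3, which also carries an unsubstituted ring amine, is the only hint, and it is confounded by the other differences. A moderate rise is therefore expected in this assay, a 1.5-fold higher number from compound 1 to compound 4 (0.19 log units; within the scatter), with wide uncertainty. Compound 4 is estimated at 850 nM, expected between 300 nM and 2500 nM.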

Compound 4, half-maximal inhibitory concentration: 420 nM
The estimate for compound 4 lay 2.0-fold (0.31 log units) above the measured number; measured number inside the range.
By their numbers in this assay, from the lowest: compounds 4, 1, 2 and 3 (each within the scatter of the next, the first and the last beyond it).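

In this assay the position on the aromatic carbon opposite the ring oxygen, ortho to an acetyl group, takes 1,4-diazepan-1-yl in place of 4-ethylpiperazin-1-yl with a 1.3-fold lower number from compound 1 to compound 4 (0.12 log units; within the scatter), so compounds 1 and 4 cannot be told apart. Going by these compounds alone, this is the first reading at this position with the acetyl group and the fluoro on the pyrimidine held constant: the move from a six-membered to a seven-membered ring, with the hydrogen-bond donor counted for 1,4-diazepan-1-yl, leaves the number within the scatter. Nothing measured here accounts for this outcome.

The step changes ring size and the ethyl group together, so the two contributions stay unseparated; a 4-ethyl-1,4-diazepan-1-yl group on the core of compound 1 would bear on that directly. On these data alone, it also remains open how far this position extends beyond cyclic diamines, for instance to a morpholine ring or an open-chain 2-(dimethylamino)ethylamino group, and whether the flat response seen here would hold for them.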